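Half-life notes: heteroaryl ring in place of amide chain

The compounds below may be only part of what the source reports. "The series", "measured", "known", "first", "only" and "open" are said of these compounds alone.

Measured so far:
compound 1 `CC(C)NC(=O)CC(c1ccc(-c2ccc3cccc(F)c3c2)[nH]c1=O)C(C)C`, 0.32 h
compound 2 `CCn1ncc2c(F)cc(-c3ccc(C(CC)(CC)c4nnc(C)[nH]4)c(=O)[nH]3)cc21`, > 3 h
compound 3 `CC(C)[C@H](C[C@H]1CCNC1=O)c1ccc(-c2ccc3cccc(F)c3c2)[nH]c1=O`, 0.257 h

In an ADME assay on microsomes from liver (Homo sapiens) for metabolic stability (a lower number here means that the compound disappears faster, a higher number that the compound lasts longer), compound 1 gives 0.32 h. Compound 3 gives 0.257 h in this assay, and the two numbers sit within the scatter of each other, so no order between compound 1 and compound 3 can be read from them. The value of compound 2 in this assay is a limit, not a number; it sits at the limit of > 3 h in this assay, at which 1 of the 3 values shown sits. Compound 2 also differs from the other two in its core, so nothing about a single change can be drawn from it.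

Compound 4 `CC(C)C(c1noc(=O)[nH]1)c1ccc(-c2ccc3cccc(F)c3c2)[nH]c1=O` is the next member and has not yet been measured in this assay. Relative to compound 1 the change is a group of 6 heavy atoms (2 carbon, 2 nitrogen, 2 oxygen; one five-membered aromatic ring with 3 hetero atoms) in place of a group of 7 heavy atoms (5 carbon, 1 nitrogen, 1 oxygen; no ring), on a saturated chain carbon bound to an aromatic carbon and a saturated chain carbon

Within the data shown here, no measured pair shows this kind of change, so the size of the step is open. The expectation for compound 4 is a small gain in this assay, with the step of a 1.6-fold higher number from compound 1 to compound 4 (0.19 log units; within the scatter) not clearly beyond the scatter. The estimate for compound 4 is 0.5 h, within 0.2 h to 1.5 h.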

Compound 4, half-life: > 3 h
Compound 4 ended at the assay's limit; the forecaster's own chance of this, stated with the estimate: 10%; middle value at least 6.0-fold (0.77 log units) from the limit.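

At the saturated chain carbon bound to an aromatic carbon and a saturated chain carbon, replacing the (isopropylcarbamoyl)methyl group with the five-membered aromatic ring with 3 hetero atoms gives, in this assay, an at least 9.3-fold higher number from compound 1 to compound 4 (0.97 log units; beyond the scatter). Compound 4 gives > 3 h, which is a limit of the assay and not a number, so the step sets only a minimum size. The values of compound 1 and compound 3 sit within the scatter of each other, whereas this change at the same position separates clearly and reaches the top of the read-out: the limit of > 3 h in this assay, at which 2 of the 4 values shown sit.

From the compounds shown here alone, how far the half-life of compound 4 extends beyond that limit stays open. Also open, going by these compounds, is what a carboxylic acid or a primary amine on the same carbon would give in this assay.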